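Alkyl variation at the amine of a butyltelluro phenethylamine series

The compounds below may be only part of what the source reports. "The series", "measured", "known", "first", "only" and "open" are said of these compounds alone.

Compound 1 `CCCC[Te]c1ccc(C(C)NCc2ccccc2)cc1` gave 11.4 ug/mL in a functional assay, read by spectrophotometry, with a stated time of 30 min; on this read-out lower numbers stand for stronger inhibition and higher numbers for weaker inhibition.
Compound 2 `CCCC[Te]c1ccc(C(C)NCC(C)C)cc1` gave 12.5 ug/mL in this assay.
Compound 3 `C=CCNC(C)c1ccc([Te]CCCC)cc1` gave > 100 ug/mL in this assay, a limit of the assay and not a number.

Compound 3 thus stands apart from the other two, which sit close together: the step of an at least 8.7-fold higher number from compound 1 to compound 3 (0.94 log units; beyond the scatter) and the step of an at least 8.0-fold higher number from compound 2 to compound 3 (0.90 log units; beyond the scatter) both run beyond the scatter, whereas a 1.1-fold higher number from compound 1 to compound 2 (0.04 log units; within the scatter) does not. Compound 3 sits at the limit of > 100 ug/mL in this assay, at which 1 of the 3 values shown sits.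

Compound 4 `CCCCNC(C)c1ccc([Te]CCCC)cc1` has not yet been measured in this assay. It differs from compound 3 by propyl in place of vinyl on a saturated chain carbon bound to an amine nitrogen. Going by the values given here, the steps that bear on it are those into compound 3, above all an at least 8.0-fold higher number from compound 2 to compound 3 (0.90 log units; beyond the scatter), where a saturated branched group was replaced by the vinyl group that compound 4 now loses. Reversing that kind of change is expected to lower the number again, so compound 4 is expected to show an at least 4.0-fold lower number from compound 3 to compound 4 (0.60 log units; beyond the scatter) in this assay. Compound 4 is estimated at 25 ug/mL, within a range from 8 ug/mL to 100 ug/mL.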

Compound 4, half-maximal inhibitory concentration: 8.63 ug/mL
For compound 4 the middle estimate is 2.9-fold (0.46 log units) above the measured one, and the stated range covers the measured number.
By their numbers in this assay, from the lowest: compounds 4, 1 and 2 (each within the scatter of the next). At a limit, above all of these: compound 3.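

Replacing vinyl with propyl, on a saturated chain carbon bound to an amine nitrogen, gives an at least 11-fold lower number from compound 3 to compound 4 (1.06 log units; beyond the scatter) in this assay and shows that this single change at this place is enough to separate compound 3 from the rest. Propyl also joins the earlier saturated and aromatic groups, with a 1.4-fold lower number from compound 2 to compound 4 (0.16 log units; within the scatter) and a 1.3-fold lower number from compound 1 to compound 4 (0.12 log units; within the scatter) both showing that compounds 1, 2 and 4 form one group here, against which compound 3 alone stands apart. On these data alone, the value of compound 3 remains a limit of the assay and not a number, and the size of its step stays open-ended: the limit of > 100 ug/mL in this assay, at which 1 of the 4 values shown sits.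

What the compounds shown leave open is whether a methyl, an ethyl or a longer chain such as hexyl would stay with that group. Nor do they tell whether a propargyl group or a hydroxyl on the chain would behave like vinyl or like propyl.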